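Trifluoromethoxy replaces fluoro on the fluorophenyl arm

A few compounds are considered here, and "the series" means these few. Any claim that something is new, unique, unknown or untested is made for them only; others in the source may bear on it.

Compound 1 `Oc1ccc(-c2cc(-c3ccccc3F)cc(-c3cccc(O)c3)n2)cc1` is the strongest of the numbers shown in a functional assay on DU-145 cells (Homo sapiens) for inhibition; a higher number here means a weaker inhibitor, a lower number a stronger inhibitor: compound 1 gives 3160 nM. Compound 2 `Oc1ccc(-c2cc(-c3ccc(F)cc3)cc(-c3cccc(O)c3)n2)cc1` gives 15200 nM, which is a 4.8-fold higher number from compound 1 to compound 2 (0.68 log units; beyond the scatter). Compound 3 `Oc1ccc(-c2cc(-c3ccc(C(F)(F)F)cc3)cc(-c3cccc(O)c3)n2)cc1` does not give a number at all; its value in this assay is a limit, > 50000 nM, described by the limit of > 50000 nM in this assay, at which 1 of the 3 values shown sits. The step from compound 2 to compound 3 is an at least 3.2-fold higher number from compound 2 to compound 3 (0.51 log units; beyond the scatter), and the combined step is an at least 15-fold higher number from compound 1 to compound 3 (1.19 log units; beyond the scatter).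

Compound 4 `Oc1ccc(-c2cc(-c3ccccc3OC(F)(F)F)cc(-c3cccc(O)c3)n2)cc1` is not yet measured. It differs from compound 1 in one place: trifluoromethoxy in place of fluoro on an aromatic carbon. Among the compounds with values here, no measured step enlarges the substituent at this place, which is on an aromatic carbon ortho to a large group. Within the data shown here, the steps that bear on it replace fluoro by a larger fluorinated group, as in an at least 3.2-fold higher number from compound 2 to compound 3 (0.51 log units; beyond the scatter), or move fluoro away, as in a 4.8-fold higher number from compound 1 to compound 2 (0.68 log units; beyond the scatter), and both weaken inhibition. The author therefore expects compound 4 to be a weaker inhibitor than compound 1 by a modest margin, a 2.5-fold higher number from compound 1 to compound 4 (0.40 log units; beyond the scatter). The estimated value for compound 4 is 8000 nM, with a range from 3000 nM to 25000 nM.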

Compound 4, half-maximal inhibitory concentration: 7760 nM
The estimate for compound 4 lay 1.0-fold (0.01 log units) above the measured number; the range from low to high includes it.
By their numbers in this assay, from the lowest: compound 1; then compounds 4 and 2 (each within the scatter of the next). At a limit, above all of these: compound 3.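

In this assay, this is the first step shown that enlarges the group on the aromatic carbon ortho to a large group: trifluoromethoxy, with 5 heavy atoms, replaces fluoro, with 1, and the result is a 2.5-fold higher number from compound 1 to compound 4 (0.39 log units; beyond the scatter). So fluoro is not required at this place, as compound 4 still gives a measured 7760 nM and not a limit, although inhibition is weaker than with compound 1. No measurement shown here accounts for this step.

With only fluoro and trifluoromethoxy shown at this place, two groups cannot tell whether the change in inhibition follows the size of the group or something else about it. From the compounds shown here alone, how a plain methoxy or an amine would behave at the same place remains open.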